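A few compounds are considered here, and "the series" means these few. Any claim that something is new, unique, unknown or untested is made for them only; others in the source may bear on it.

In an assay on isolated protein for inhibition of sodium-dependent dopamine transporter (Rattus norvegicus), read by radioligand binding (on this read-out higher numbers stand for weaker inhibition and lower numbers for stronger inhibition), compound 2 `CN1CCC(c2ccc(Cl)cc2)C(C[S+]([O-])CC(=O)NO)C1` gives 55 nM and stands alongside compound 1 `COCCSCC1CN(C)CCC1c1ccc(Cl)cc1`, which gives 50 nM, the two numbers within the scatter of each other. Compound 3 `CNC(=O)C[S+]([O-])CC1CN(C)CCC1c1ccc(Cl)cc1` differs from compound 2 by methyl in place of hydroxy on an amide-type nitrogen. Within the data shown here, the only measured step, a 1.1-fold higher number from compound 1 to compound 2 (0.04 log units; within the scatter), exchanged the whole group on the saturated chain carbon bound to the saturated ring carbon and leaves the amide-type nitrogen untested, so nothing measured bears directly on this change. In this assay a step no larger than the scatter is expected, a 1.1-fold higher number from compound 2 to compound 3 (0.04 log units; within the scatter). Compound 3 is therefore estimated at 60 nM, between 25 nM and 150 nM.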

Compound 3, inhibition constant: 164 nM
The estimate for compound 3 lay 2.7-fold (0.44 log units) below the measured number; measured number outside the range, above it.
By their numbers in this assay, from the lowest: compounds 1 and 2 (each within the scatter of the next); then compound 3.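

In this assay, among these compounds, this is the first read on the amide-type nitrogen: methyl in place of hydroxy gives a change beyond the scatter (a 3.0-fold higher number from compound 2 to compound 3 (0.47 log units; beyond the scatter)). The group on the saturated chain carbon therefore matters in its detail: compound 2 stays within the scatter of compound 1, whereas the (methylcarbamoyl)methyl group does not (a 3.3-fold higher number from compound 1 to compound 3 (0.52 log units; beyond the scatter)). Nothing at hand explains this step. The compounds shown leave open whether a plain carbamoyl, a methoxy on the same nitrogen or a carboxylic acid would stay with compound 2 or with compound 3.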